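Swapping the dipropylamino group for a ring on the shared core

The source may hold more compounds than are shown below. What is called first, only, known or untested is meant among the compounds shown, and "the series" means these compounds.

Measured so far:
- compound 1, `CCCN(CCC)c1nc(C(F)(F)F)ccc1CNC(=O)C(C)c1ccc(NS(C)(=O)=O)c(F)c1`: 14.7 nM
- compound 2, `C[C@H](C(=O)NCc1ccc(C(F)(F)F)nc1N1CCC[C@H]1CO)c1ccc(NS(C)(=O)=O)c(F)c1`: "not active" (no number reported)

Going by the values given here, compound 1 is the only compound here with a number. In a functional assay on CHO-K1 cells for antagonist activity at transient receptor potential cation channel subfamily V member 1 (Homo sapiens), read by FLIPR (on this read-out higher numbers stand for weaker inhibition and lower numbers for stronger inhibition), compound 1 gives 14.7 nM. Among the compounds with values here, compound 2 carries a different group on the same part of the core and was reported in this assay as "not active" (no number reported); no number came with that result, so it cannot be compared on a scale with compound 1, and no step between measured compounds can be worked out.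

The compound that is still to be tested is compound 3, `CC(C(=O)NCc1ccc(C(F)(F)F)nc1N1CCC(C(F)(F)F)CC1)c1ccc(NS(C)(=O)=O)c(F)c1`. It differs from compound 1 in one place: 4-(trifluoromethyl)piperidin-1-yl in place of dipropylamino on an aromatic carbon. The rest of the molecule, including the amide and the methanesulfonamide part, is unchanged.

Within the data shown here, with only one number to lean on, the expectation is a modest step: compound 3 is expected to be somewhat weaker than compound 1, with the estimated step of a 1.9-fold higher number from compound 1 to compound 3 (0.28 log units; within the scatter) lying close to the edge of the usual scatter. The estimate for compound 3 in this assay is 28 nM, between 7 nM and 110 nM.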

Compound 3, half-maximal inhibitory concentration: 31 nM
Compound 3: middle estimate off by 1.1-fold (0.04 log units), on the low side, and the stated range covers the measured number.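

Putting 4-(trifluoromethyl)piperidin-1-yl in place of dipropylamino gives a 2.1-fold higher number from compound 1 to compound 3 (0.32 log units; beyond the scatter) in this assay, a modest step. This shows that the open chains of compound 1 are not required for a measured number at this position, next to the ring nitrogen, since compound 3 carries a six-membered ring there and still gives a value. Compound 2 also carries a ring at this position but came without a number, so no step to it can be read and the presence of a ring alone does not decide the outcome, while nothing measured here accounts for the step from dipropylamino to the ring.

The compounds shown leave open whether the change in the number comes from the ring or from its trifluoromethyl group, a question that plain piperidin-1-yl, carrying no trifluoromethyl, would bear on directly. They also leave open how this position would respond to a morpholin-4-yl ring or to a shorter open chain such as diethylamino.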